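Phenyl for Neopentyl: Expected Effect on Microsomal Clearance

This account rests on a few compounds, and the source may have more. Where it says the series, first, only, none or still open, it means among the compounds named here.

Measured compounds:
compound 1 `Cc1cccc([C@@H](O)C(=O)N2N=CC[C@H]2C(=O)NCc2cc(Cl)ccc2-n2cnnn2)c1` gives < 12 mL.min-1.g-1
compound 2 `CC(C)(C)C[C@@H](O)C(=O)N1CC[C@@H]2C[C@@]21C(=O)NCc1cc(Cl)ccc1-n1cnnn1` gives 27 mL.min-1.g-1
compound 3 `CC(C)CC[C@@H](O)C(=O)N1N=CC[C@H]1C(=O)NCc1cc(Cl)ccc1-n1cnnn1` gives 47 mL.min-1.g-1

All three were tested in an ADME assay on liver for metabolic stability, with Liver microsome (Homo sapiens) as the target, read by LC-MS, using microsomes; a lower number here means slower removal, a higher number faster removal of the compound. The value of compound 1 is a limit of the assay, not a number. Among the two numbers, compound 2 stands lowest; its nearest neighbour is compound 3, and the gap between compound 2 and compound 3 lies within the usual scatter.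

Compound 4 `O=C([C@H](O)c1ccccc1)N1CC[C@@H]2C[C@@]21C(=O)NCc1cc(Cl)ccc1-n1cnnn1` differs from compound 2 in one place: phenyl in place of neopentyl on a saturated chain carbon bound to a carbonyl carbon and an oxygen on a saturated carbon.

For the measured compounds named here, one measured step bears on this: an at least 3.9-fold higher number from compound 1 to compound 3 (0.59 log units; beyond the scatter). There an aromatic ring at the same place was replaced by a branched alkyl chain and the clearance number rose by at least a modest amount. The change from compound 2 to compound 4 runs the other way, from a branched alkyl group to an aromatic ring, so a lower number in this assay is expected, of roughly the size seen in that step.

Compound 4 is therefore estimated at 10 mL.min-1.g-1, with a range from 4 mL.min-1.g-1 to 25 mL.min-1.g-1, which would mean an expected step of a 2.7-fold lower number from compound 2 to compound 4 (0.43 log units; beyond the scatter).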

Compound 4, intrinsic clearance in microsomes: 43 mL.min-1.g-1
For compound 4 the middle estimate is 4.3-fold (0.63 log units) below the measured one; the measured number lies above the stated range.
By their numbers in this assay, from the lowest: compounds 2, 4 and 3 (each within the scatter of the next). At a limit, below all of these: compound 1.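

In this assay, placing phenyl instead of neopentyl on this saturated chain carbon gives a 1.6-fold higher number from compound 2 to compound 4 (0.20 log units; within the scatter), so on this core the change produces no readable difference in clearance. The earlier step, an at least 3.9-fold higher number from compound 1 to compound 3 (0.59 log units; beyond the scatter), was measured on a different core with a different aromatic ring and a different alkyl group, and the lower number it gave the aromatic compound does not carry over to this pair. As far as these compounds go, the value of compound 1 is a limit of the assay, not a number, so the true size of that earlier step stays open: the limit of < 12 mL.min-1.g-1 in this assay, at which 1 of the 4 values shown sits.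

From the compounds shown here alone, whether phenyl and neopentyl would also lie within the scatter of each other on the core of compound 1 remains open. So does the effect on clearance of an amine or a carboxylic acid on this same chain carbon.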